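Changing the benzamide aryl group of compound 1

The source may report more compounds than this note shows. Statements on the series, on what has been measured and on what is new or still open speak of the compounds shown alone.

Compound 1 `CNc1nc(Nc2ccc(C)c([N+](=O)[O-])c2)ncc1C(=O)Nc1cc(NC(=O)c2cccc(C(F)(F)F)c2)ccc1C` was tested in a functional assay on K562 cells (Homo sapiens) for antiproliferative activity, read by CellTiter-Glo and CCK-8 assay, with a stated time of 72 h (a higher number here means a weaker inhibitor of growth, a lower number a stronger inhibitor of growth), where compound 1 gives 52 nM. Among the three measured compounds it holds the second highest number: compound 3 `CNc1nc(Nc2ccc(C)c(N)c2)ncc1C(=O)Nc1cc(NC(=O)c2cccc(C(F)(F)F)c2)ccc1C`, in which amino replaces nitro on an aromatic carbon, gives 14 nM, while compound 2 `Cc1ccc(NC(=O)c2cccc(C(F)(F)F)c2)cc1NC(=O)c1cnc(Nc2ccc(C)c([N+](=O)[O-])c2)nc1`, which lacks the methylamino group on the shared core, gives 380 nM. Both measured steps run from compound 1 and both lie beyond the scatter: a 7.3-fold higher number from compound 1 to compound 2 (0.86 log units; beyond the scatter), and a 3.7-fold lower number from compound 1 to compound 3 (0.57 log units; beyond the scatter).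

Compound 4 `CNc1nc(Nc2ccc(C)c([N+](=O)[O-])c2)ncc1C(=O)Nc1cc(NC(=O)c2ccccc2OC)ccc1C` differs from compound 1 at a different place altogether: 2-methoxyphenyl in place of 3-(trifluoromethyl)phenyl on a carbonyl carbon. Neither of the measured steps touches this part of the molecule; one concerns the methylamino group on the core and the other the nitro group, so the measured data say nothing direct about how the benzamide aryl group may be varied. For the measured compounds named here, with no comparable step available, the expectation for compound 4 rests on the structural change alone, and the estimate must carry a wide range. A somewhat higher number than that of compound 1 is expected for compound 4, a 5.8-fold higher number from compound 1 to compound 4 (0.76 log units; beyond the scatter), with the possibility that the change is within the scatter kept open. Compound 4 is therefore estimated at 300 nM, with a range from 60 nM to 1500 nM.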

Compound 4, concentration for 50% growth inhibition: > 10000 nM
Compound 4: only a limit was reported; the forecaster's own chance of this, stated with the estimate: 3%; middle value at least 33-fold (1.52 log units) away from the limit.
By their numbers in this assay, from the lowest: compound 3; then compound 1; then compound 2. At a limit, above all of these: compound 4.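

The benzamide aryl group, which neither earlier step touched, proves far less forgiving in this assay than the two places varied before, with 2-methoxyphenyl in place of 3-(trifluoromethyl)phenyl on a carbonyl carbon giving an at least 190-fold higher number from compound 1 to compound 4 (2.28 log units; beyond the scatter). For compound 4 the reading is a limit of the assay and not a number: the limit of > 10000 nM in this assay, at which 1 of the 4 values shown sits. The earlier single changes, at the methylamino group and the nitro group, each left a measured number, so this is the first change shown that reaches the limit, and the largest step so far.

Both the group that leaves and the group that enters differ in this one step, so compound 4 alone does not tell whether the 3-(trifluoromethyl)phenyl group is needed or the 2-methoxyphenyl group is what fails here. On these data alone, how a plain phenyl, a 3-methoxyphenyl or a 3-chlorophenyl group would fare on the same carbonyl carbon stays open, as does whether amino in place of nitro would bring a 2-methoxyphenyl compound back to a measurable number.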